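Difluorophenyl Ketone Variant of a Trimethoxyphenyl Pyrazole Chalcone

This account rests on a few compounds, and the source may have more. Where it says the series, first, only, none or still open, it means among the compounds named here.

Measured compounds in a functional assay on MDA-MB-435 cells (Homo sapiens) for cytotoxicity, read by sulforhodamine B assay, with a stated time of 48 h, tested at 10 uM; on this read-out lower numbers stand for a stronger effect and higher numbers for a weaker effect at the one concentration tested:
compound 1 `COc1cc(-c2cc(/C=C/C(=O)c3ccc(N)cc3)[nH]n2)cc(OC)c1OC` gives -86%
compound 2 `COc1ccc(C(=O)/C=C/c2cc(-c3cc(OC)c(OC)c(OC)c3)n[nH]2)cc1OC` gives -92%
compound 3 `COc1ccc(C(=O)/C=C/c2cc(-c3cc(OC)c(OC)c(OC)c3)n[nH]2)cc1` gives -30%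

Compound 3 stands at the highest of the three numbers in this assay, that is the weakest effect. Its nearest neighbour is compound 1, with a number 56 percentage points higher from compound 1 to compound 3 (beyond the scatter); its furthest is compound 2, with a number 62 percentage points higher from compound 2 to compound 3 (beyond the scatter). Both of these steps alter only the ring on the carbonyl carbon, and both are large.

Compound 4 `COc1cc(-c2cc(/C=C/C(=O)c3ccc(F)c(F)c3)[nH]n2)cc(OC)c1OC` differs from compound 3 in that same place: 3,4-difluorophenyl in place of 4-methoxyphenyl on a carbonyl carbon. For the measured compounds named here, no measured step replaces a methoxy with fluorine, so no step bears directly on this change. What the steps to compound 1 and compound 2 show is that this ring governs the size of the effect in this assay strongly, in either direction. Compound 4 is therefore expected to move back toward a stronger effect, with wide uncertainty, by a number 25 percentage points lower from compound 3 to compound 4 (beyond the scatter). The estimate for compound 4 in this assay is -55%, within a range from -95% to -10%.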

Compound 4, a percentage reported as activity, at one concentration (the size of the read-out at that concentration, not a potency): 5%
Beside the measured number, compound 4's estimate is 60 percentage points below it; measured number above the stated range.
By their numbers in this assay, from the lowest: compounds 2 and 1 (each within the scatter of the next); then compound 3; then compound 4.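

In this assay, the ring on the carbonyl carbon does more than set how strong the effect is: 3,4-difluorophenyl in place of 4-methoxyphenyl gives a number 35 percentage points higher from compound 3 to compound 4 (beyond the scatter), and compound 4, at 5%, is the only one of the four with a number above zero. The same ring gives a number 97 percentage points higher from compound 2 to compound 4 (beyond the scatter) in place of 3,4-dimethoxyphenyl and a number 91 percentage points higher from compound 1 to compound 4 (beyond the scatter) in place of 4-aminophenyl, so this one position spans the whole range seen among these compounds. Nothing at hand explains why the difluorinated ring gives the weakest effect of the four.

The compounds shown leave open whether both fluorines are needed for this loss, since a 4-fluorophenyl ring does not appear among them. They also leave open where a plain phenyl or a 4-hydroxyphenyl ring on the carbonyl carbon would fall.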